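This account rests on a few compounds, and the source may have more. Where it says the series, first, only, none or still open, it means among the compounds named here.

In an in vitro ADME assay on microsomes from liver (Homo sapiens) for metabolic stability (a lower number here means slower removal, a higher number faster removal of the compound), compound 3 `CCNC(=O)[C@H]1CC[C@@H](n2/c(=N/C(=O)c3ccccc3)[nH]c3ccc(CN4CCCCC4)cc32)CC1` gives 194 mL.min-1.g-1. Compound 2 `CC(C)NC(=O)[C@H]1CC[C@@H](n2/c(=N/C(=O)c3ccc(F)cc3)[nH]c3ccc(CN4CC(C(C)(C)O)C4)cc32)CC1` gives 105 mL.min-1.g-1. The gap between compound 2 and compound 3 lies within the scatter. Compound 1 `COC(=O)[C@H]1CC[C@@H](n2/c(=N/C(=O)c3ccccc3)[nH]c3ccc(CN4CCCCC4)cc32)CC1` gives 85 mL.min-1.g-1. The gap between compound 1 and compound 3 lies beyond the scatter, with compound 1 on the lower side.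

The next structure is compound 4 `CCOC(=O)[C@H]1CC[C@@H](n2/c(=N/C(=O)c3ccccc3)[nH]c3ccc(CN4CCCCC4)cc32)CC1`, which carries this change: ethoxy in place of ethylamino on a carbonyl carbon.

For the measured compounds named here, one measured step bears on this: a 2.3-fold higher number from compound 1 to compound 3 (0.36 log units; beyond the scatter), a modest step with ethylamino in place of methoxy on a carbonyl carbon. Going by the values given here, the new change runs the opposite way, though it ends on ethoxy, not methoxy, and no measured step compares those two groups. Compound 2 differs from compound 3 in more than one place, so it offers no direct guide. A modest move to a lower number in this assay is therefore expected, similar in size to the measured step.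

The expected change is a 2.0-fold lower number from compound 3 to compound 4 (0.31 log units; beyond the scatter).

The estimated value for compound 4 is 95 mL.min-1.g-1, with an expected range of 50 mL.min-1.g-1 to 180 mL.min-1.g-1.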

Compound 4, intrinsic clearance in microsomes: 222 mL.min-1.g-1
Estimate against measurement, compound 4: 2.3-fold (0.37 log units) below; the measured number lies above the stated range.
By their numbers in this assay, from the lowest: compounds 1, 2, 3 and 4 (each within the scatter of the next, the first and the last beyond it).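

In this assay, ethoxy in place of ethylamino on a carbonyl carbon gives a 1.1-fold higher number from compound 3 to compound 4 (0.06 log units; within the scatter), so at this position ethylcarbamoyl and ethoxycarbonyl are not separated, even though the change removes the hydrogen-bond donor counted on ethylamino. Methoxy and ethoxy on the same carbonyl carbon do separate, with a 2.6-fold higher number from compound 1 to compound 4 (0.42 log units; beyond the scatter), and together with a 2.3-fold higher number from compound 1 to compound 3 (0.36 log units; beyond the scatter) this leaves compound 1 apart from the other two, so the earlier step cannot be read as a simple swap of oxygen for nitrogen. No measurement shown here accounts for this difference.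

From the compounds shown here alone, it remains open whether the number follows the chain on this carbonyl carbon or whether methoxy alone stands apart. Methylamino, a longer chain such as propoxy, or the free carboxylic acid at this carbon would help separate these readings.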